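The source may report more compounds than this note shows. Statements on the series, on what has been measured and on what is new or still open speak of the compounds shown alone.

Among the compounds with values here, in a functional assay on MCF7 cells (Homo sapiens) for cytotoxicity, read by MTT assay, with a stated time of 72 h (on this read-out lower numbers stand for stronger inhibition and higher numbers for weaker inhibition), compound 2 `COc1ncc(-c2ccc3nc(NC(=O)NC4CC4)nn3c2)cc1NS(=O)(=O)c1ccc(F)cc1` gives 300 nM and holds the lower of the two numbers so far, while compound 1 `COc1ncc(-c2ccc3nc(NC(=O)N4CCCC4)nn3c2)cc1NS(=O)(=O)c1ccc(F)cc1` gives 1660 nM as the higher one. Compound 3 `COc1ncc(-c2ccc3nc(NC(=O)NCCN(C)C)nn3c2)cc1NS(=O)(=O)c1ccc(F)cc1` differs from compound 2 at one place (2-(dimethylamino)ethyl in place of cyclopropyl on an amide-type nitrogen) with 2-(dimethylamino)ethyl in place of cyclopropyl on an amide-type nitrogen. Within the data shown here, the only measured step bearing on this change is a 5.5-fold lower number from compound 1 to compound 2 (0.74 log units; beyond the scatter) and it is modest. It shows that groups on this carbonyl can move the number, but it gives no firm direction for a chain without a ring, so only a cautious rise is expected. The expected change is a 1.7-fold higher number from compound 2 to compound 3 (0.22 log units; within the scatter) as an estimate only. Compound 3 is estimated at 500 nM with an expected range of 130 nM to 1900 nM on this scale.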

Compound 3, half-maximal inhibitory concentration: 560 nM
Compound 3: middle estimate off by 1.1-fold (0.05 log units), on the low side; the range from low to high includes it.
By their numbers in this assay, from the lowest: compounds 2 and 3 (each within the scatter of the next); then compound 1.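

In this assay the open chain 2-(dimethylamino)ethyl and the ring cyclopropyl on this amide-type nitrogen cannot be told apart, with a 1.9-fold higher number from compound 2 to compound 3 (0.27 log units; within the scatter) as the step between them. Against pyrrolidin-1-yl on the carbonyl carbon, the chain gives a 3.0-fold lower number from compound 1 to compound 3 (0.47 log units; beyond the scatter) as its step, so a lower number than that of compound 1 does not require a cyclopropyl ring here. No outside evidence explains these numbers. From the compounds shown here alone, whether a longer chain, or a carboxylic acid in place of the dimethylamino group, would hold this level remains open.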